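The compounds below may be only part of what the source reports. "The series", "measured", "known", "first", "only" and "open" are said of these compounds alone.

The measured compounds:
Compound 1, `C=CC1=C(C(=O)NC(C)(C)C)C(c2ccc(OC)cc2)OC1`, in a functional assay on QGY7701 cells (Homo sapiens) for cytotoxicity, read by MTT assay, with a stated time of 24 h (a lower number here means a stronger inhibitor, a higher number a weaker inhibitor), gives > 100000 nM, which is a limit of the assay and not a number.
Compound 2, `C=CC1=C(C(=O)Nc2ccc(OCC)cc2)C(c2ccc(F)cc2)OC1`, in this assay gives 61600 nM.
Compound 3, `C=CC1=C(C(=O)O)C(c2ccc(OC)cc2)OC1`, in this assay gives > 100000 nM, again a limit of the assay.

Compound 1 therefore stands only at a limit: its reading is one of the two values sitting at the limit of > 100000 nM in this assay, at which 2 of the 3 values shown sit, so no number is known for it. Among the measured compounds shown here, the single measured step that starts from it, a step that the two limits leave unreadable from compound 1 to compound 3, cannot be read in size; both of its ends are limits. For the measured compounds named here, compound 2 is the only compound with a number, and it carries an amide bearing an aromatic group rather than the tert-butyl amide of compound 1.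

Compound 4 is `C=CC1=C(C(=O)NCc2ccccc2F)C(c2ccc(OC)cc2)OC1`. It differs from compound 1 by 2-fluorobenzyl in place of tert-butyl on an amide-type nitrogen. Going by the values given here, no measured step bears directly on this change; the only step from compound 1 is unreadable, and compound 2 shows merely that an amide with an aromatic group can give a number within the range of the assay. The expectation for compound 4 in this assay is weak activity, a step of an at least 1.2-fold lower number from compound 1 to compound 4 (0.09 log units; that floor lies within the scatter) that may be no more than the scatter. Compound 4 is estimated at 80000 nM, with a range from 30000 nM to 200000 nM, and a good chance that only a limit is reported.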

Compound 4, half-maximal inhibitory concentration: > 100000 nM
Compound 4: a limit, no number; the forecaster's own chance of this, stated with the estimate: 55%; at least 1.2-fold (0.09 log units) between middle value and limit.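

In this assay compound 4 gives > 100000 nM, which is a limit of the assay and not a number. No size can be read for the step between compound 1 and compound 4, as both values are limits: the limit of > 100000 nM in this assay, at which 3 of the 4 values shown sit.

The compounds shown leave open whether 2-fluorobenzyl and tert-butyl on the amide-type nitrogen differ at all in this assay.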